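This account rests on a few compounds, and the source may have more. Where it says the series, first, only, none or still open, it means among the compounds named here.

Three close analogues share one core and differ only in the group on the sulfonyl sulfur. Compound 1 `Cc1ccccc1S(=O)(=O)Nc1ccc2oc(-c3ccccc3)nc2c1` carries a 2-methylphenyl there, compound 2 `O=S(=O)(Nc1ccc2oc(-c3ccccc3)nc2c1)c1cccc(Cl)c1` a 3-chlorophenyl, and compound 3 `COc1ccccc1S(=O)(=O)Nc1ccc2oc(-c3ccccc3)nc2c1` a 2-methoxyphenyl. In an assay on isolated protein for inhibition of malate dehydrogenase, mitochondrial (Sus scrofa), with stated times of 45 min and 30 min (a lower number here means a stronger inhibitor, a higher number a weaker inhibitor), compound 1 gives > 63000 nM, which is a limit of the assay rather than a number. Compound 2 likewise reaches only the limit > 63000 nM. Compound 3, too, stands at the limit > 63000 nM. Because of the limit of > 63000 nM in this assay, at which 3 of the 3 values shown sit, none of the steps among these three can be read: the step that the two limits leave unreadable from compound 1 to compound 2, the step that the two limits leave unreadable from compound 1 to compound 3 and the step that the two limits leave unreadable from compound 2 to compound 3 all remain of unknown size. Compound 4 `O=S(=O)(Nc1ccc2oc(-c3ccccc3)nc2c1)c1cccc(O)c1` brings the next change: 3-hydroxyphenyl in place of 2-methoxyphenyl on a sulfonyl sulfur. Among the compounds with values here, none of the measured steps resolves a size, so nothing points to a step beyond the scatter in this assay. The expected step of a number no higher from compound 3 to compound 4 (the limit leaves the size open) is therefore near zero, with a wide spread. Compound 4 is expected to give about 63000 nM, within 20000 nM to 200000 nM, and most likely again only as a limit.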

Compound 4, half-maximal inhibitory concentration: > 63000 nM
Compound 4 ended at the assay's limit (the forecaster's own chance of this, stated with the estimate: 75%); the middle value sits exactly at the limit.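

The steps from compound 1, compound 2 and compound 3 to compound 4 cannot be read, because all four compounds stop at the same assay limit: the limit of > 63000 nM in this assay, at which 4 of the 4 values shown sit.

The compounds shown leave open how strongly any of these four inhibits in this assay, and whether the group on the sulfonyl sulfur matters there.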